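Removing the Phenyl from a Benzyl Arm: An Efficacy Estimate

A few compounds are considered here, and "the series" means these few. Any claim that something is new, unique, unknown or untested is made for them only; others in the source may bear on it.

Of the compounds shown here, three have been measured in an in vitro functional assay on 1321-N1 cells for agonist activity at Free fatty acid receptor 1 (Homo sapiens), read by fluorescence, spectrophotometry and calcium flux; on this read-out higher numbers stand for larger maximal responses and lower numbers for smaller maximal responses. Compound 1, `O=C(O)CCc1ccc(C#Cc2ccnc(Cl)c2Cc2ccccc2)cc1`, gives 101% in this assay . Compound 2, `Cc1cc(C#Cc2ccc(CCC(=O)O)cc2)nc(Cl)n1`, gives 110%, and compound 3, `O=C(O)CCc1ccc(C#Cc2cccnc2)cc1`, gives 96%. All three numbers sit close together: the value of compound 1 lies near that of compound 3 and near that of compound 2, and each of these gaps is within the usual scatter of repeated measurements, so none of the three can be called more or less efficacious than another on this evidence.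

Compound 4, `Cc1c(C#Cc2ccc(CCC(=O)O)cc2)ccnc1Cl`, has not yet been measured in this assay . It differs from compound 1 in one place: hydrogen in place of phenyl on a saturated chain carbon bound to an aromatic carbon. Within the data shown here, no measured pair in this set reports such a change directly, so its effect on the largest response is not yet known.

Given that compound 1, compound 2 and compound 3 all reach roughly the full response of the reference, no step beyond the scatter is expected from compound 1 to compound 4; the expected step is a number 1 percentage points lower from compound 1 to compound 4 (within the scatter). Compound 4 is therefore estimated at 100%, with a range from 85% to 115%.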

Compound 4, largest response reached (reported as efficacy), in percent of the reference or control that the assay uses: 101%
Compound 4: middle estimate off by 1 percentage points, on the low side; low and high end bracket the measured number.
By their numbers in this assay, from the lowest: compounds 3, 1, 4 and 2 (each within the scatter of the next, the first and the last beyond it).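

In this assay, hydrogen in place of phenyl on a saturated chain carbon bound to an aromatic carbon, which reads as benzyl to methyl, brings no change at the digits printed from compound 1 to compound 4 (within the scatter). Among these compounds, this gives the first direct reading of this position: a phenyl of six carbon atoms can leave the core of compound 1, and the largest response of the pair stays within the scatter, so on this read-out the maximal response does not depend on that phenyl. Nothing measured here accounts for this outcome.

On these data alone, whether an amine or a carboxylic acid on the same saturated chain carbon, or a longer chain in place of the methyl, would hold the response in the same way remains open. Also open, as far as these compounds go, is whether this exchange would read the same on a different core, and how it affects the concentration needed to reach the response, which a maximal response alone cannot tell.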